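This account rests on a few compounds, and the source may have more. Where it says the series, first, only, none or still open, it means among the compounds named here.

Compound 1 `CNC(=O)N1CCCc2ccc(NC(=O)c3cccc(-c4ccn(C)n4)c3)cc21` was tested in a functional assay on MV4-11 cells (Homo sapiens) for antiproliferative activity, with a stated time of 6 days, tested at 6.25 uM (on this read-out lower numbers stand for a weaker effect and higher numbers for a stronger effect at the one concentration tested), where compound 1 gives 99.5%. Compound 2 `CNC(=O)N1CCCc2ccc(NC(=O)c3ccc(-c4ccn(C)n4)cc3)cc21` shares the same atoms joined differently; how its core differs from that of compound 1 is not broken down here. In this assay compound 2 gives 97%. Compound 3 `CNC(=O)N1CCCc2ccc(NC(=O)c3cccc(-c4cnn(C)c4)c3)cc21` carries the change (1-methyl-1H-pyrazol-4-yl in place of 1-methyl-1H-pyrazol-3-yl on an aromatic carbon), and this change made the step of a number 6 percentage points lower from compound 1 to compound 3 (within the scatter). In this assay compound 3 gives 93.5%. Compound 4 `CNC(=O)N1CCCc2ccc(NC(=O)c3ccc(-c4cnn(C)c4)cc3)cc21` has not yet been measured. It carries the same kind of change, (1-methyl-1H-pyrazol-4-yl in place of 1-methyl-1H-pyrazol-3-yl on an aromatic carbon), but here the place is para to a large group rather than meta to a large group. The step for compound 4 is expected to be a number 5 percentage points lower from compound 2 to compound 4 (within the scatter), resting on the earlier step of a number 6 percentage points lower from compound 1 to compound 3 (within the scatter). For compound 4 the estimated result is 92%, expected to fall between 84% and 99%.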

Compound 4, a percentage reported as inhibition, at one concentration (the size of the read-out at that concentration, not a potency): 94.4%
The estimate for compound 4 lay 2.4 percentage points below the measured number; the range from low to high includes it.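

In this assay, replacing 1-methyl-1H-pyrazol-3-yl with 1-methyl-1H-pyrazol-4-yl gives this step: a number 2.6 percentage points lower from compound 2 to compound 4 (within the scatter). The same change therefore behaves alike on both cores, with neither step standing out from the scatter and the two steps agreeing: the same change on two cores in this assay, a number 6 percentage points lower (within the scatter) from compound 1 to compound 3 and a number 2.6 percentage points lower (within the scatter) from compound 2 to compound 4, 3.4 percentage points apart, within the scatter of two such steps. This does not show that the change leaves the effect untouched at other concentrations, as the read-out gives the size of the effect at one concentration, so a stronger or weaker effect at other concentrations could go unseen.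

The compounds shown carry only methylpyrazole rings at this place, so it stays open how an amine, a carboxylic acid or a longer chain there would fare. On these data alone, whether lower concentrations would separate these four compounds also stays open.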